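A few compounds are considered here, and "the series" means these few. Any claim that something is new, unique, unknown or untested is made for them only; others in the source may bear on it.

Three thiosemicarbazones sharing one core have been measured in a functional assay on T47D cells (Homo sapiens) for cytotoxicity, read by MTT assay, with a stated time of 48 h; on this read-out lower numbers stand for stronger inhibition and higher numbers for weaker inhibition. Compound 1 `Fc1ccc(NC(=S)N/N=C\c2ccnc3ccccc23)cc1` gives 1070 nM. Compound 2 `O=[N+]([O-])c1ccc(NC(=S)N/N=C\c2ccnc3ccccc23)cc1` gives 1330 nM, the second highest of the three numbers; its nearest neighbour is compound 3 `S=C(N/N=C\c1ccnc2ccccc12)Nc1ccc(Br)cc1`, which gives 1480 nM. Every step among them stays within the scatter: a 1.2-fold higher number from compound 1 to compound 2 (0.09 log units; within the scatter), a 1.4-fold higher number from compound 1 to compound 3 (0.14 log units; within the scatter) and a 1.1-fold higher number from compound 2 to compound 3 (0.05 log units; within the scatter). Compound 4 `CCc1ccc(NC(=S)N/N=C\c2ccnc3ccccc23)cc1` has not yet been measured in this assay. It differs from compound 2 by ethyl in place of nitro on an aromatic carbon. The three measured steps bear directly on this change, since each swaps the group on the same aromatic carbon, and none of them moved the number beyond the scatter. Among the compounds with values here, no measured step introduces ethyl, so compound 4 carries somewhat more uncertainty than the measured exchanges, but on the evidence the expected step of a 1.1-fold lower number from compound 2 to compound 4 (0.04 log units; within the scatter) should not exceed the scatter in either direction. Compound 4 is therefore estimated at 1200 nM, in a range from 600 nM to 2400 nM.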

Compound 4, half-maximal inhibitory concentration: 1280 nM
Estimate against measurement, compound 4: 1.1-fold (0.03 log units) below; the measured number falls inside the stated range.
By their numbers in this assay, from the lowest: compounds 1, 4, 2 and 3 (each within the scatter of the next).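

In this assay, ethyl, which has no hydrogen-bond acceptors, replaces nitro, which has two, on the aromatic carbon para to a large group, and the result is a 1.0-fold lower number from compound 2 to compound 4 (0.02 log units; within the scatter) for this exchange. The two halogen comparisons read the same way, with a 1.2-fold lower number from compound 3 to compound 4 (0.06 log units; within the scatter) against bromo and a 1.2-fold higher number from compound 1 to compound 4 (0.08 log units; within the scatter) against fluoro, so a plain carbon chain now joins nitro and the halogens among the groups at this position with no step beyond the scatter. Nothing available here accounts for why these four numbers stay so close.

Going by these compounds, whether an amine, a carboxylic acid or a longer chain such as hexyl on this carbon would also stay within the scatter remains open. So does what a change elsewhere on the shared core would do to the number.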